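Compound 4 and the Missing Value of Compound 3

A few compounds are considered here, and "the series" means these few. Any claim that something is new, unique, unknown or untested is made for them only; others in the source may bear on it.

In a toxicity assay on NIH3T3 cells (Mus musculus) for cytotoxicity, read by resazurin assay (a higher number here means that more compound is needed for the effect, a lower number that less compound is needed), compound 3 `COC(=O)c1ccc(NCc2cncn2Cc2cccc(-c3ccccc3)c2)cc1-c1ccccc1` has no single number, and its entry reads "not determined" (no result reported). Compound 1 `COC(=O)c1ccc(NCc2cncn2Cc2ccccc2)cc1-c1ccccc1` gives > 1000 nM, which is a limit of the assay. Compound 2 `COC(=O)c1ccc(NCc2cncn2Cc2cccc([N+](=O)[O-])c2)cc1-c1ccccc1` gives > 10000 nM, which is also a limit. The step to compound 4 `COC(=O)c1ccc(NCc2cncn2Cc2ccc(C)cc2)cc1-c1ccccc1` places 4-methylphenyl in place of 3-phenylphenyl on a saturated chain carbon bound to an aromatic nitrogen. Within the data shown here, the one measured step, a step that the two limits leave unreadable from compound 1 to compound 2, exchanges hydrogen for nitro on an aromatic carbon and has no readable size. No step size or direction can therefore be expected in this assay from compound 3. Compound 4 is estimated at 5000 nM, with an expected range of 1000 nM to 25000 nM.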

Compound 4, half-maximal effective concentration: 50000 nM
The estimate for compound 4 lay 10-fold (1.00 log units) below the measured number, and the stated range ends below it.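

No new step can be read: compound 1 and compound 2 carry only limits, which leaves their steps to compound 4 unreadable. The compounds shown leave open how far compound 4 lies from either, and where compound 3 stands.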